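A trifluoromethoxy swap at the assay limit

The compounds below may be only part of what the source reports. "The series", "measured", "known", "first", "only" and "open" are said of these compounds alone.

Compound 1 `COc1cccc(NC(=O)c2cc(=O)[nH]c3cc(Br)ccc23)c1`: > 20000 nM
Compound 2 `O=C(Nc1cccc(Cl)c1)c1cc(=O)[nH]c2cc(Br)ccc12`: > 20000 nM

In a functional assay on KYSE-410 cells (Homo sapiens) for antiproliferative activity, read by MTT assay, with a stated time of 72 h (on this read-out higher numbers stand for weaker inhibition and lower numbers for stronger inhibition), compound 1 gives > 20000 nM as a limit of the assay, not a number. Compound 2 gives > 20000 nM as a limit too. With the limit of > 20000 nM in this assay, at which 2 of the 2 values shown sit, as all there is, compound 2 stands only at a limit. For the measured compounds named here, the one measured step that the two limits leave unreadable from compound 1 to compound 2 has no size that can be carried over.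

Compound 3 `O=C(Nc1cccc(OC(F)(F)F)c1)c1cc(=O)[nH]c2cc(Br)ccc12` has trifluoromethoxy in place of chloro on an aromatic carbon relative to compound 2. Resting on compound 2 with its limit of > 20000 nM and on no readable step, in this assay no step beyond the scatter is expected, in either direction. The step expected is a number no higher from compound 2 to compound 3 (the limit leaves the size open) by this estimate. For compound 3 the estimated value is 20000 nM (expected range 9000 nM to 40000 nM).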

Compound 3, half-maximal inhibitory concentration: 14000 nM
Estimate against measurement, compound 3: 1.4-fold (0.15 log units) above; measured number inside the range.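

In this assay compound 3 gives 14000 nM, the first number in this set and the first reading at this position that is not a limit: the limit of > 20000 nM in this assay, at which 2 of the 3 values shown sit.

Trifluoromethoxy in place of chloro gives an at least 1.4-fold lower number from compound 2 to compound 3 (0.15 log units; that floor lies within the scatter), and trifluoromethoxy in place of methoxy gives an at least 1.4-fold lower number from compound 1 to compound 3 (0.15 log units; that floor lies within the scatter); both are floors, so neither step yet shows a change beyond the scatter. The step between the other two compounds still cannot be read, since both of its values are limits.

As far as these compounds go, how far compound 1 and compound 2 actually lie past their limits stays open, and with it the true size of both steps. Also open, from the compounds shown here alone, is how an amine or a nitrile would read on this aromatic carbon, meta to a large group, on the shared core.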